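Sulfonamide aryl swap on the shared core

The source may report more compounds than this note shows. Statements on the series, on what has been measured and on what is new or still open speak of the compounds shown alone.

Measured so far in a functional assay on 143B cells (Homo sapiens) for antiproliferative activity, read by MTT assay, with a stated time of 48 h; a lower number here means a stronger inhibitor, a higher number a weaker inhibitor:
- compound 1 `O=C(/C=C/c1cccc(NC(=O)c2ccccc2Cl)c1)c1nc2ccccc2[nH]1`: 3690 nM
- compound 2 `O=C(Nc1cccc(/C=C/C(=O)c2nc3ccccc3[nH]2)c1)c1cccc(Cl)c1`: 3370 nM
- compound 3 `O=C(/C=C/c1cccc(NS(=O)(=O)c2ccc(Cl)cc2)c1)c1nc2ccccc2[nH]1`: 7450 nM

Compound 3 stands highest of the three numbers in this assay. The gap to its nearest neighbour is a 2.0-fold higher number from compound 1 to compound 3 (0.31 log units; beyond the scatter), and the gap to its furthest neighbour is a 2.2-fold higher number from compound 2 to compound 3 (0.34 log units; beyond the scatter). Compound 1 and compound 2 sit together, a 1.1-fold lower number from compound 1 to compound 2 (0.04 log units; within the scatter).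

Compound 4 `Cc1ccccc1S(=O)(=O)Nc1cccc(/C=C/C(=O)c2nc3ccccc3[nH]2)c1` differs from compound 3 in one place: 2-methylphenyl in place of 4-chlorophenyl on a sulfonyl sulfur. Among the compounds with values here, no measured step changes the aryl group on a sulfonyl sulfur; the two sulfonamide-bearing steps swap the whole carbonyl for sulfonyl, and the remaining step moves chlorine on a carbonyl-linked ring and stays within the scatter. Nothing here bears directly on the change from compound 3 to compound 4, so no step beyond the scatter is expected in this assay, with wide uncertainty. The estimated step is a 1.1-fold lower number from compound 3 to compound 4 (0.03 log units; within the scatter). Compound 4 is expected to give about 7000 nM in this assay, with a range from 2800 nM to 18000 nM.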

Compound 4, half-maximal inhibitory concentration: 4060 nM
Beside the measured number, compound 4's estimate is 1.7-fold (0.24 log units) above it; the measured number falls inside the stated range.
By their numbers in this assay, from the lowest: compounds 2, 1, 4 and 3 (each within the scatter of the next, the first and the last beyond it).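

In this assay, within the data shown here, the first change of aryl group on a sulfonyl sulfur, 2-methylphenyl in place of 4-chlorophenyl, gives a 1.8-fold lower number from compound 3 to compound 4 (0.26 log units; within the scatter), so this swap shows no separation beyond the scatter. The sulfonyl link alone therefore does not set a sulfonamide apart from the amides: with 2-methylphenyl on the sulfur, the readings are a 1.2-fold higher number from compound 2 to compound 4 (0.08 log units; within the scatter) and a 1.1-fold higher number from compound 1 to compound 4 (0.04 log units; within the scatter), whereas compound 3 lies beyond the scatter of both amides. No evidence at hand accounts for these numbers.

The swap changes both the substituent and its ring position, so 4-methylphenyl and 2-chlorophenyl on the sulfonyl sulfur would be needed to separate the two. Also open, from the compounds shown here alone, is how this position responds to an aminophenyl group, a carboxyphenyl group or an open butyl chain in place of the aryl ring.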